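This account rests on a few compounds, and the source may have more. Where it says the series, first, only, none or still open, it means among the compounds named here.

Measured so far in this series:
- compound 1, `CCCc1nc(CC)c(C(=O)OCC(=O)c2ccccc2)n1Cc1ccc(-c2ccccc2S(=O)(=O)NC(=O)OCCC(C)C)cc1F`: 2 nM
- compound 2, `CCCc1nc(CC)c(C(=O)OCc2ccccc2OCCC(C)C)n1Cc1ccc(-c2ccccc2S(=O)(=O)NC(=O)OCCC(C)C)cc1F`: 10 nM
- compound 3, `CCCc1nc(CC)c(C(=O)OCc2ccccc2NC(=O)c2ccccc2)n1Cc1ccc(-c2ccccc2S(=O)(=O)NC(=O)OCCC(C)C)cc1F`: 1 nM

In an assay on isolated protein for binding affinity to Type-2 angiotensin II receptor (Homo sapiens) (a lower number here means a stronger inhibitor, a higher number a weaker inhibitor), compound 2 stands highest of the three numbers; compound 1 lies nearer, compound 3 furthest. Both steps at the ester-bearing position that have been measured run beyond the scatter: a 5.0-fold higher number from compound 1 to compound 2 (0.70 log units; beyond the scatter) and a 10-fold lower number from compound 2 to compound 3 (1.00 log units; beyond the scatter). Each change away from the 2-(isopentyloxy)phenyl group of compound 2 has so far given a lower number.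

Compound 4, `CCCc1nc(CC)c(C(=O)OCCC[S+]([O-])c2ccccc2)n1Cc1ccc(-c2ccccc2S(=O)(=O)NC(=O)OCCC(C)C)cc1F`, is not yet measured. Relative to compound 2 the change is a group of 10 heavy atoms (8 carbon, 1 oxygen, 1 sulfur; one six-membered aromatic ring of carbon only) in place of a group of 12 heavy atoms (11 carbon, 1 oxygen; one six-membered aromatic ring of carbon only), on a saturated chain carbon bound to an oxygen next to a carbonyl group. The entering group keeps one aromatic ring and one hydrogen-bond acceptor, as the leaving group does, but is two heavy atoms smaller and carries its acceptor on sulfur rather than on an ether oxygen. The two measured steps bear on this position only loosely, since neither exchanged group resembles the entering one; they do show that compound 2 is the weak member and that departures from it have lowered the number.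

On that basis a moderately lower number is expected for compound 4, a step of a 2.5-fold lower number from compound 2 to compound 4 (0.40 log units; beyond the scatter) in this assay. The estimate for compound 4 is 4 nM, with a range from 1.2 nM to 14 nM.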

Compound 4, half-maximal inhibitory concentration: 1 nM
For compound 4 the middle estimate is 4.0-fold (0.60 log units) above the measured one; measured number below the stated range.
By their numbers in this assay, from the lowest: compounds 3, 4 and 1 (each within the scatter of the next); then compound 2.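

In this assay, a 10-fold lower number from compound 2 to compound 4 (1.00 log units; beyond the scatter), so a third, different departure from the 2-(isopentyloxy)phenyl group of compound 2 lowers the number, and no compound shown goes against this. The group of 10 heavy atoms, which carries its acceptor on sulfur, gives a 2.0-fold lower number from compound 1 to compound 4 (0.30 log units; within the scatter) and so cannot be told apart from the benzoyl group of compound 1; on this saturated chain carbon, compounds 3, 4 and 1 form one run, each within the scatter of the next, and only compound 2 stands apart. Nothing available explains why these groups fall together or why compound 2 stands apart.

Still open, on these data alone, is whether the oxygen on sulfur matters, which the matching thioether or sulfone would test. Also open, as far as these compounds go, is whether the isopentyloxy chain itself sets compound 2 apart, which a methoxy group in its place would test.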